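A few compounds are considered here, and "the series" means these few. Any claim that something is new, unique, unknown or untested is made for them only; others in the source may bear on it.

In a physicochemical assay for solubility, read by HPLC, in phosphate buffer, at pH 6.5 (on this read-out lower numbers stand for lower solubility and higher numbers for higher solubility), compound 1 `COC(=O)C1=C(C)NC(c2nccs2)=NC1(C)c1ccc(OC)cc1` gives 106 ug/mL, compound 2 `COC(=O)C1=C(C)NC(c2nccs2)=NC1(C)c1ccc(F)c(F)c1` gives 50 ug/mL and compound 3 `COC(=O)C1=C(CN2CCNCC2)NC(c2nccs2)=NC1(C)c1ccc(F)cc1` gives 250 ug/mL. Compound 3 thus has the highest of the three numbers, and its gap to each of the other two lies beyond the scatter.

Compound 4 `COC(=O)C1=C(CN2CCC(C(F)(F)F)C2)NC(c2nccs2)=NC1(C)c1ccc(F)cc1` differs from compound 3 in one place: 3-(trifluoromethyl)pyrrolidin-1-yl in place of piperazin-1-yl on a saturated chain carbon bound to a double-bonded ring carbon. The swap sits on a saturated chain carbon bound to a double-bonded ring carbon.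

Within the data shown here, no measured step covers a change at that place. Among the measured compounds shown here, the only step available, a 2.1-fold lower number from compound 1 to compound 2 (0.33 log units; beyond the scatter), is modest and concerns a saturated ring carbon, so it offers only a weak guide. More can be drawn from the values: compound 1 at 106 ug/mL and compound 2 at 50 ug/mL have no piperazin-1-yl group, whereas compound 3 carries that group and gives 250 ug/mL, the highest of the three numbers. A fall larger than that modest step is therefore expected in this assay, and the estimate is a 5.6-fold lower number from compound 3 to compound 4 (0.74 log units; beyond the scatter). Compound 4 is expected at about 45 ug/mL, with an estimated range of 12 ug/mL to 130 ug/mL.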

Compound 4, solubility: 13 ug/mL
For compound 4 the middle estimate is 3.5-fold (0.54 log units) above the measured one; low and high end bracket the measured number.
By their numbers in this assay, from the lowest: compound 4; then compound 2; then compound 1; then compound 3.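

In this assay, the swap gives a 19-fold lower number from compound 3 to compound 4 (1.28 log units; beyond the scatter) and is the first change shown at the saturated chain carbon bound to a double-bonded ring carbon, so the group at this place can move the number by a large amount. The swap alters several things at once: a six-membered non-aromatic ring with 2 hetero atoms and 1 hydrogen-bond donor leaves, while a five-membered non-aromatic ring with 1 hetero atom, 0 hydrogen-bond donors and a trifluoromethyl group enters. Nothing available ties the fall to any one of these differences.

The compounds shown do not separate the loss of the piperazine ring from the arrival of the trifluoromethyl group. Plain pyrrolidin-1-yl, without the trifluoromethyl group, would separate the two, and morpholin-4-yl at the same place would test a six-membered ring with a ring oxygen.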